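Swapping the aryl group of a PDI inhibitor

The source may hold more compounds than are shown below. What is called first, only, known or untested is meant among the compounds shown, and "the series" means these compounds.

Measured compounds in an assay for inhibition of protein disulfide-isomerase (Homo sapiens), with a stated time of 1 h; on this read-out lower numbers stand for stronger inhibition and higher numbers for weaker inhibition:
- compound 1 `Cc1cc(C)c(C(Nc2ccccn2)c2ccc3cccnc3c2O)c(C)c1`: 190 nM
- compound 2 `Oc1ccc2[nH]ncc2c1C(c1ccc(F)cc1)N1CCCCC1`: 350 nM
- compound 3 `Cc1ccnc(NC(c2cc(C)ccc2C)c2ccc3cccnc3c2O)c1`: > 40000 nM, a limit of the assay rather than a number

In this assay compound 1 and compound 2 give numbers that lie within the usual scatter of each other, so neither can be called the stronger inhibitor. Compound 3 reaches only a limit (the limit of > 40000 nM in this assay, at which 1 of the 3 values shown sits). Compound 4 `COc1cccc(C(Nc2ccccn2)c2ccc3cccnc3c2O)c1` has not yet been measured. It differs from compound 1 in one place: 3-methoxyphenyl in place of 2,4,6-trimethylphenyl on a saturated chain carbon bound to an aromatic carbon and a nitrogen on an aromatic ring. Among the compounds with values here, no measured pair shows the effect of such a change, so the expected step in this assay, from compound 1 to compound 4, is a 7.9-fold higher number from compound 1 to compound 4 (0.90 log units; beyond the scatter) toward weaker inhibition, and it is uncertain. Compound 4 is therefore estimated at 1500 nM, with a range from 300 nM to 10000 nM.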

Compound 4, half-maximal inhibitory concentration: 2860 nM
Beside the measured number, compound 4's estimate is 1.9-fold (0.28 log units) below it, and the stated range covers the measured number.
By their numbers in this assay, from the lowest: compounds 1 and 2 (each within the scatter of the next); then compound 4. At a limit, above all of these: compound 3.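

In this assay the aryl group on this saturated chain carbon clearly matters: 3-methoxyphenyl in place of 2,4,6-trimethylphenyl gives a 15-fold higher number from compound 1 to compound 4 (1.18 log units; beyond the scatter) and so a large move toward weaker inhibition. This is the only pair shown that differs in one place, which makes it the only direct reading of this position. Nothing measured here explains the size of this step.

The swap removes the methyl groups and adds a methoxy group together, so the step cannot be assigned to either part. On these data alone, how a plain phenyl or a 4-chlorophenyl group would fare at this position remains open.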